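Swapping bromo for methyl in an antiproliferative series

The source may report more compounds than this note shows. Statements on the series, on what has been measured and on what is new or still open speak of the compounds shown alone.

Compound 1 `Cc1ccc(S(=O)(=O)NC(=O)c2cccnc2)cc1`: 18500 nM
Compound 2 `O=C(NS(=O)(=O)c1ccc(Br)cc1)c1ccncc1`: 8800 nM

In a functional assay on B16-F10 cells (Mus musculus) for antiproliferative activity, read by colorimetric assay and MTT assay, with a stated time of 48 h (on this read-out higher numbers stand for weaker inhibition and lower numbers for stronger inhibition), compound 2 has the lower of the two numbers, at 8800 nM. Compound 3 `Cc1ccc(S(=O)(=O)NC(=O)c2ccncc2)cc1` has not yet been measured. It carries methyl in place of bromo on an aromatic carbon, para to a large group (methyl in place of bromo on an aromatic carbon). Going by the values given here, no measured pair shows this change alone. Compound 1 also carries methyl and gives 18500 nM, which points towards a higher number. A small upward step is therefore expected, a 1.6-fold higher number from compound 2 to compound 3 (0.20 log units; within the scatter), not clearly beyond the scatter. Compound 3 is estimated at 14000 nM, with an expected range of 6000 nM to 32000 nM.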

Compound 3, half-maximal inhibitory concentration: 16200 nM
Estimate against measurement, compound 3: 1.2-fold (0.06 log units) below, and the stated range covers the measured number.
By their numbers in this assay, from the lowest: compounds 2, 3 and 1 (each within the scatter of the next, the first and the last beyond it).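

In this assay, methyl in place of bromo on an aromatic carbon, para to a large group, gives a 1.8-fold higher number from compound 2 to compound 3 (0.27 log units; within the scatter) and so does not clearly separate the two groups at this position. Pyridin-4-yl in place of pyridin-3-yl on a carbonyl carbon gives a 1.1-fold lower number from compound 1 to compound 3 (0.06 log units; within the scatter) and likewise leaves the two compounds indistinguishable on this read-out. Nothing available explains either step.

Still open, on these data alone, is whether an amine or a carboxylic acid at the para position would move the number beyond the scatter. As far as these compounds go, the effect of pyridin-3-yl in place of pyridin-4-yl alongside bromo also remains open.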